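A Second Methoxy on the Aryl Ring

The source may hold more compounds than are shown below. What is called first, only, known or untested is meant among the compounds shown, and "the series" means these compounds.

Two measured compounds share one core and differ only in a substituent on a six-membered aromatic ring of carbon only. Compound 1 `Cc1ccc(S(=O)(=O)N(C)c2ccc3[nH]c(-c4n[nH]c5ccccc45)cc3n2)cc1` carries a methyl there, while compound 2 `COc1ccc(S(=O)(=O)N(C)c2ccc3[nH]c(-c4n[nH]c5ccccc45)cc3n2)cc1` carries a methoxy. In a functional assay on HCT-116 cells (Homo sapiens) for antiproliferative activity, read by MTT assay, with a stated time of 72 h (on this read-out higher numbers stand for weaker inhibition and lower numbers for stronger inhibition), compound 1 gives 13300 nM, and compound 2 gives 22400 nM. The move a 1.7-fold higher number from compound 1 to compound 2 (0.23 log units; within the scatter) lies within the usual scatter, so the two figures cannot be told apart with confidence. Going by the values given here, of the two numbers known, compound 2 has the larger one, with compound 1 as its nearest neighbour at a gap within the scatter.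

Compound 3 `COc1ccc(S(=O)(=O)N(C)c2ccc3[nH]c(-c4n[nH]c5ccccc45)cc3n2)cc1OC` extends compound 2 by a single alteration: methoxy in place of hydrogen on an aromatic carbon. Among the compounds with values here, no measured step adds a methoxy to a ring that already bears one, so the only guide is the methyl-to-methoxy exchange between compound 1 and compound 2, which was indistinguishable from scatter. On that basis the step of a 1.1-fold higher number from compound 2 to compound 3 (0.05 log units; within the scatter) is expected to be small and of uncertain direction. The estimate for compound 3 is 25000 nM, within a range from 10000 nM to 70000 nM.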

Compound 3, half-maximal inhibitory concentration: 16700 nM
Compound 3: middle estimate off by 1.5-fold (0.18 log units), on the high side, and the stated range covers the measured number.
By their numbers in this assay, from the lowest: compounds 1, 3 and 2 (each within the scatter of the next).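

In this assay, adding a second methoxy on the aromatic carbon ortho to a methoxy group and meta to a large group gives a 1.3-fold lower number from compound 2 to compound 3 (0.13 log units; within the scatter), so this position accepts the new group with no difference that can be told from the scatter. Replacing the whole aryl group, with 3,4-dimethoxyphenyl in place of 4-methylphenyl on the sulfonyl sulfur, gives a 1.3-fold higher number from compound 1 to compound 3 (0.10 log units; within the scatter), which shows that the 4-methylphenyl, 4-methoxyphenyl and 3,4-dimethoxyphenyl forms cannot be separated on this read-out. No measurement shown here offers an explanation for how closely these numbers lie.

The three compounds leave open whether a different group on this aromatic carbon, such as an amine or a carboxylic acid, would move the number beyond the scatter. They also leave open whether the added methoxy would give a similarly small step on the ring of compound 1, which carries a methyl where compound 2 carries a methoxy.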